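This account rests on a few compounds, and the source may have more. Where it says the series, first, only, none or still open, it means among the compounds named here.

Compound 1, `COC(=O)C(=O)/C=C(\O)c1ccc(Cl)c(C)c1`, gives 4900 nM in an assay for inhibition of kynurenine 3-monooxygenase (Rattus norvegicus); on this read-out higher numbers stand for weaker inhibition and lower numbers for stronger inhibition. Compound 2, `COC(=O)C(=O)/C=C(\O)c1ccc(Cl)c([N+](=O)[O-])c1`, gives 11200 nM in this assay. Compound 3, `Cc1cc(/C(O)=C/C(=O)C(=O)O)ccc1Cl`, gives 1700 nM in this assay.

The change from compound 1 to compound 2 is nitro in place of methyl on an aromatic carbon, and it made a step of a 2.3-fold higher number from compound 1 to compound 2 (0.36 log units; beyond the scatter). The two cores differ by hydrogen in place of methyl on an oxygen next to a carbonyl group, which made a step of a 2.9-fold lower number from compound 1 to compound 3 (0.46 log units; beyond the scatter). Compound 4, `O=C(O)C(=O)/C=C(\O)c1ccc(Cl)c([N+](=O)[O-])c1`, is not yet measured; it differs from compound 3 by nitro in place of methyl on an aromatic carbon. This is the same kind of change as that between compound 1 and compound 2, though not the same: in compound 3 the place is meta to a group of 8 heavy atoms, in compound 1 meta to a group of 9 heavy atoms. Resting on the step of a 2.3-fold higher number from compound 1 to compound 2 (0.36 log units; beyond the scatter), the step from compound 3 to compound 4 is expected to be about a 2.3-fold higher number from compound 3 to compound 4 (0.36 log units; beyond the scatter). Compound 4 is therefore estimated to give 3900 nM in this assay, most likely between 1900 nM and 8000 nM.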

Compound 4, half-maximal inhibitory concentration: 2000 nM
Beside the measured number, compound 4's estimate is 2.0-fold (0.29 log units) above it; the measured number falls inside the stated range.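

Nitro in place of methyl on an aromatic carbon gave a 1.2-fold higher number from compound 3 to compound 4 (0.07 log units; within the scatter), and this step does not differ from the one on the core of compound 1: the same change on two cores in this assay, a 2.3-fold higher number (0.36 log units; beyond the scatter) from compound 1 to compound 2 and a 1.2-fold higher number (0.07 log units; within the scatter) from compound 3 to compound 4, 1.9-fold (0.29 log units) apart, within the scatter of two such steps. Hydrogen in place of methyl on an oxygen next to a carbonyl group gave a 5.6-fold lower number from compound 2 to compound 4 (0.75 log units; beyond the scatter), and it too agrees with its earlier counterpart: the same change on two cores in this assay, a 2.9-fold lower number (0.46 log units; beyond the scatter) from compound 1 to compound 3 and a 5.6-fold lower number (0.75 log units; beyond the scatter) from compound 2 to compound 4, 1.9-fold (0.29 log units) apart, within the scatter of two such steps. Among the compounds shown here, both changes therefore carried between these two cores in this assay, but each comparison rests on only two steps, which does not show that either change would carry to any other core.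

The compounds shown leave open how an amine or a trifluoromethyl group at the same place would compare. They also leave open what an amide in place of the carboxylic acid would give.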